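Swapping the benzyl arm of compound 1 for cyclohexyl

The compounds below may be only part of what the source reports. "The series", "measured", "known", "first", "only" and "open" are said of these compounds alone.

Compound 1 `Fc1ccc(Cc2ccc3c(NCCCNCc4ccco4)ccnc3c2)c(Cl)c1` gives 5730 nM in an ADME assay on HepG2 cells (Homo sapiens) for cytotoxicity, read by luminescence, CellTiter-Glo and ATP content, with a stated time of 72 h; on this read-out higher numbers stand for an effect only at larger amounts of compound and lower numbers for an effect already at smaller amounts.
Compound 2 `COc1ccc(F)cc1CNCCCNc1ccnc2cc(Cc3ccc(F)cc3Cl)ccc12` gives 2460 nM in this assay.
Compound 3 `COc1cccc(CNCCCNc2ccnc3cc(-c4ccc(F)cc4)ccc23)c1O` gives 6840 nM in this assay.

Compound 1 sits second highest of these three numbers; compound 3 lies within the scatter of it, while compound 2 lies beyond it, the step being a 2.3-fold lower number from compound 1 to compound 2 (0.37 log units; beyond the scatter). That single measured step concerns the amine end of the molecule, not the aromatic carbon of the core.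

Compound 4 `c1coc(CNCCCNc2ccnc3cc(C4CCCCC4)ccc23)c1` differs from compound 1 only there: cyclohexyl in place of 2-chloro-4-fluorobenzyl on an aromatic carbon. Going by the values given here, no measured step touches this position, so the data give no direction for it. Compound 4 is therefore expected to stay near compound 1, with a 1.1-fold lower number from compound 1 to compound 4 (0.06 log units; within the scatter) not beyond the scatter. The estimate for compound 4 is 5000 nM, within a range from 1800 nM to 14000 nM.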

Compound 4, half-maximal effective concentration: 4760 nM
Compound 4: the middle estimate sits 1.1-fold (0.02 log units) above what was measured, within the range that was stated.
By their numbers in this assay, from the lowest: compounds 2, 4, 1 and 3 (each within the scatter of the next, the first and the last beyond it).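

In this assay, going by these compounds alone, cyclohexyl in place of 2-chloro-4-fluorobenzyl on this aromatic carbon brings a 1.2-fold lower number from compound 1 to compound 4 (0.08 log units; within the scatter), the only measured step at this position. For this pair, then, the aromatic benzyl arm with its chlorine and fluorine can give way to a non-aromatic ring of carbon only, with fewer heavy atoms, without a shift beyond the scatter. No evidence bears on why this exchange leaves the number within the scatter.

On these data alone, what an amine or a carboxylic acid on this aromatic carbon would do remains open. So does whether cyclohexyl behaves the same way alongside the 5-fluoro-2-methoxyphenyl amine end of compound 2.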